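Adding a second chloro group to compound 2

The source may hold more compounds than are shown below. What is called first, only, known or untested is meant among the compounds shown, and "the series" means these compounds.

Three compounds have been measured so far in a functional assay on HUVEC cells (Homo sapiens) for inhibition, with a stated time of 4 days (a lower number here means a stronger inhibitor, a higher number a weaker inhibitor), and give these values
- compound 1 `COc1ccc(C(N)=O)cc1/C=C/c1ccc(Cl)cc1` with 87 nM
- compound 2 `COc1ccc(C(N)=O)cc1/C=C/c1cccc(Cl)c1` with 24000 nM
- compound 3 `COc1ccc(C(N)=O)cc1/C=C/c1cccc(C#N)c1` with 49000 nM

Compound 2 holds the second highest of the three numbers. It lies close to compound 3 and far above compound 1. Compound 4 `COc1ccc(C(N)=O)cc1/C=C/c1ccc(Cl)c(Cl)c1` differs from compound 2 by one change (chloro in place of hydrogen on an aromatic carbon), with chloro in place of hydrogen on an aromatic carbon. The new chloro group stands ortho to a chloro group and para to a large group.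

Among the measured compounds shown here, the only measured step between compounds differing in one place is a 2.0-fold higher number from compound 2 to compound 3 (0.31 log units; beyond the scatter) and it is modest. It swaps the existing chloro group for cyano, so it says little about this new place. For the measured compounds named here, compound 1 (87 nM) is the closer guide, since its single chloro group also stands para to a large group. Compound 2 (24000 nM) lacks a group there. Going by the values given here, no measured compound shows how the two chloro groups combine, so a large fall is expected, probably stopping short of compound 1.

The estimated change is a 20-fold lower number from compound 2 to compound 4 (1.30 log units; beyond the scatter) in this assay as a whole. The expected value for compound 4 is 1200 nM with an estimated range from 150 nM to 12000 nM in this reading.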

Compound 4, half-maximal inhibitory concentration: 560 nM
The estimate for compound 4 lay 2.1-fold (0.33 log units) above the measured number, and the stated range covers the measured number.
By their numbers in this assay, from the lowest: compound 1; then compound 4; then compound 2; then compound 3.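

In this assay, among the compounds shown here, the new chloro group, on an aromatic carbon para to a large group and ortho to a chloro group, gives a 43-fold lower number from compound 2 to compound 4 (1.63 log units; beyond the scatter) and so provides the first measured step at this place, a large one. The other chloro group, added to a single chloro group para to a large group, gives a 6.4-fold higher number from compound 1 to compound 4 (0.81 log units; beyond the scatter) as a modest step, so among these compounds most of the difference goes with the group para to a large group, and the pair of chloro groups does not match the single chloro group of compound 1. No measurement presented here accounts for either step.

Chloro is the only group seen at this place, so it remains open whether fluoro, methyl, methoxy, an amine or a carboxylic acid there would bring a step of similar size. As far as these compounds go, it is also open whether the modest step from compound 1 belongs to chloro alone or would recur with another group, such as methyl or methoxy, in the place of the second chloro group.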